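This account rests on a few compounds, and the source may have more. Where it says the series, first, only, none or still open, it means among the compounds named here.

Working notes on the series, values in a physicochemical assay for lipophilicity, read by mass spectrometry; a higher number here means a more lipophilic compound, a lower number a more polar compound:

- compound 1 `COc1cc2c(cc1OC)C(=O)C(C(=O)Nc1ccccc1)C2`: 2.2
- compound 2 `COc1cccc(NC(=O)C2Cc3cc(OC)c(OC)cc3C2=O)c1`: 2.08
- compound 3 `CCOc1ccccc1NC(=O)C1Cc2cc(OC)c(OC)cc2C1=O`: not yet measured

Compound 1 at 2.2 lies within the scatter of compound 2 at 2.08. Compound 3 carries ethoxy in place of hydrogen on an aromatic carbon, that is, ethoxy in place of hydrogen on an aromatic carbon, ortho to a large group. Within the data shown here, the only measured step that bears on it is a number 0.12 log units lower from compound 1 to compound 2 (within the scatter), for methoxy in place of hydrogen on an aromatic carbon. That single step on a different group is thin support, so the range stays wide. A small upward move in this assay is expected, an estimated a number 0.30 log units higher from compound 1 to compound 3 (within the scatter). The estimate for compound 3 is 2.5, expected between 2.1 and 2.9.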

Compound 3, partition coefficient: 2.42
Beside the measured number, compound 3's estimate is 0.08 log units above it; the measured number falls inside the stated range.
By their numbers in this assay, from the lowest: compounds 2, 1 and 3 (each within the scatter of the next, the first and the last beyond it).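

In this assay, ethoxy in place of hydrogen on an aromatic carbon, ortho to a large group, gives a number 0.22 log units higher from compound 1 to compound 3 (within the scatter). Among these compounds, this is the first reading for ethoxy on the series, and like the methoxy step, a number 0.12 log units lower from compound 1 to compound 2 (within the scatter), it leaves the number within the scatter of compound 1. No measurement offered here accounts for this reading.

The compounds shown leave open whether an amine, a carboxylic acid or a longer chain in place of ethoxy would give a step beyond the scatter.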